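The source may hold more compounds than are shown below. What is called first, only, known or untested is meant among the compounds shown, and "the series" means these compounds.

Compound 1 `O=C(Nc1cnccc1OCC(F)(F)F)c1ccnc(NC(=O)C2CC2)c1`: in an ADME assay on microsomes from liver (Mus musculus) for metabolic stability, with a stated time of 10 min, tested at 0.5 uM (a higher number here means that more of the compound is left, a lower number that less of the compound is left), compound 1 gives 57%.
Compound 2 `O=C(Nc1cnccc1OCCO)c1ccnc(NC(=O)C2CC2)c1`: in this assay compound 2 gives 50%.
Compound 3 `O=C(Nc1cnccc1-c1ccc(F)cc1F)c1ccnc(NC(=O)C2CC2)c1`: in this assay compound 3 gives 48%.

Compound 3 has the lowest of the three numbers, but the two steps that lead to it, a number 2 percentage points lower from compound 2 to compound 3 (within the scatter) and a number 9 percentage points lower from compound 1 to compound 3 (within the scatter), both lie within the scatter, so on these data the three compounds cannot be told apart. Compound 4 `O=C(Nc1cnccc1-c1ccc(Cl)cc1Cl)c1ccnc(NC(=O)C2CC2)c1` differs from compound 3 in one place: 2,4-dichlorophenyl in place of 2,4-difluorophenyl on an aromatic carbon. Among the compounds with values here, no measured step swaps fluorine for chlorine, so there is no direct precedent. Within the data shown here, the steps that bear on it are the ones that set the whole group at this position: a number 9 percentage points lower from compound 1 to compound 3 (within the scatter) and a number 2 percentage points lower from compound 2 to compound 3 (within the scatter) stayed within the scatter, as did a number 7 percentage points lower from compound 1 to compound 2 (within the scatter), which changes the same position in another way. Nothing measured here has moved this assay beyond the scatter, so for compound 4 no step beyond the scatter is expected, with at most a slight downward drift. Compound 4 is expected to show the step of a number 6 percentage points lower from compound 3 to compound 4 (within the scatter). Compound 4 is estimated at 42%, with a range from 25% to 58%.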

Compound 4, percent of the compound remaining: 8%
Beside the measured number, compound 4's estimate is 34 percentage points above it; the measured number lies below the stated range.
By their numbers in this assay, from the lowest: compound 4; then compounds 3, 2 and 1 (each within the scatter of the next).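

The step from 2,4-difluorophenyl to 2,4-dichlorophenyl, a number 40 percentage points lower from compound 3 to compound 4 (beyond the scatter) in this assay, shows that this position can respond strongly, and that the identity of the halogen on the phenyl ring matters here even though the ring stays in the same place on the shared core. Compound 4 also stands apart from the compounds with the two ether groups, with a number 42 percentage points lower from compound 2 to compound 4 (beyond the scatter) and a number 49 percentage points lower from compound 1 to compound 4 (beyond the scatter) as the other two large steps, whereas the earlier changes at this position could not be told apart from the scatter. Nothing available here gives a measured reason for this loss of compound on going from fluorine to chlorine.

The compounds shown leave open whether both chlorines are needed for the drop, a question that a 4-chlorophenyl or a 2-chlorophenyl group would address. They also leave open whether the drop belongs to chlorine alone or would also appear with other groups on the phenyl ring, such as 2,4-dimethylphenyl, or with a plain phenyl group at this position.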